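Swapping the Amide Ring in a Sulfonylpiperidine Series

The source may report more compounds than this note shows. Statements on the series, on what has been measured and on what is new or still open speak of the compounds shown alone.

Compound 1 `CCN(CC)S(=O)(=O)c1ccc(S(=O)(=O)N2CCC[C@@H](C(=O)N3CCS(=O)(=O)CC3)C2)cc1` is tested in a functional assay on MIA PaCa-2 cells (Homo sapiens) for inhibition, read by MTT assay, with a stated time of 7 days (on this read-out higher numbers stand for weaker inhibition and lower numbers for stronger inhibition), where compound 1 gives 900 nM, the highest of the two numbers recorded. Compound 2 `CC(C)CS(=O)(=O)c1ccc(S(=O)(=O)N2CCC[C@@H](C(=O)N3CCC(F)(F)CC3)C2)cc1` gives 80 nM in this assay, a gap well beyond the scatter. Compound 3 `CCN(CC)S(=O)(=O)c1ccc(S(=O)(=O)N2CCC[C@@H](C(=O)N3CC[C@H](OC)C3)C2)cc1` keeps the core of compound 1 but carries a different ring on the carbonyl: 3-methoxypyrrolidin-1-yl in place of 1,1-dioxothiomorpholin-4-yl on a carbonyl carbon. Among the compounds with values here, no measured pair shows this exact change, so the expected step from compound 1 to compound 3 is modest, a 1.3-fold lower number from compound 1 to compound 3 (0.11 log units; within the scatter), likely within the scatter in either direction. Compound 3 is therefore estimated at 700 nM, within 250 nM to 2000 nM.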

Compound 3, half-maximal inhibitory concentration: 2460 nM
Compound 3: middle estimate off by 3.5-fold (0.55 log units), on the low side; measured number outside the range, above it.
By their numbers in this assay, from the lowest: compound 2; then compound 1; then compound 3.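

Within the data shown here, this is the first pair here that differs in one place only, so the ring on the carbonyl carbon can be read on its own. In this assay, 3-methoxypyrrolidin-1-yl in place of 1,1-dioxothiomorpholin-4-yl gives a 2.7-fold higher number from compound 1 to compound 3 (0.44 log units; beyond the scatter) and so weaker inhibition, which shows that this position is sensitive to the ring it carries. Nothing measured here explains the loss.

The swap changes the ring from six-membered to five-membered and also adds a methoxy group, and these two changes cannot be separated. Going by these compounds, whether a plain pyrrolidine or a morpholine on the same core would stay closer to compound 1 or to compound 3 remains open.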